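Dropping one methoxy from compound 2

The source may hold more compounds than are shown below. What is called first, only, known or untested is meant among the compounds shown, and "the series" means these compounds.

Three compounds have numbers in a functional assay on OVCAR-3 cells (Homo sapiens) for inhibition, read by sulforhodamine B assay, with a stated time of 48 h; a higher number here means a weaker inhibitor of growth, a lower number a stronger inhibitor of growth. Compound 1 `COc1ccc(-c2cc(/C=C/C(=O)c3ccc(N)cc3)[nH]n2)cc1` gives 2970 nM, compound 2 `COc1cc(-c2cc(/C=C/C(=O)c3ccc(N)cc3)[nH]n2)cc(OC)c1OC` gives 3370 nM, and compound 3 `COc1cc(-c2cc(/C=C/C(=O)c3ccc(Cl)c(Cl)c3)[nH]n2)cc(OC)c1OC` gives 37800 nM. Going by the values given here, compound 2 thus stands second highest of the three, with compound 1 within the scatter of it and compound 3 well beyond it; the single one-point step available, an 11-fold higher number from compound 2 to compound 3 (1.05 log units; beyond the scatter), concerns the group on the carbonyl carbon and is large. Compound 1 and compound 2 differ by two methoxy groups at once, and their values show no separation beyond the scatter.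

Compound 4 `COc1ccc(-c2cc(/C=C/C(=O)c3ccc(N)cc3)[nH]n2)cc1OC` is not yet measured. Relative to compound 2 the change is hydrogen in place of methoxy on an aromatic carbon. Among the compounds with values here, no measured step touches this position directly. The step from compound 2 to compound 3 sits on another part of the molecule and says nothing about removing a methoxy. Within the data shown here, the only guide is that compound 1 and compound 2, which differ by two methoxy groups, fall within the scatter of each other, so removing one of them is expected to give no step beyond the scatter: the expected step is a 1.1-fold lower number from compound 2 to compound 4 (0.02 log units; within the scatter), in no firm direction. Compound 4 is therefore estimated at 3200 nM in this assay, with a range from 1500 nM to 7000 nM.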

Compound 4, concentration for total growth inhibition: 4190 nM
Beside the measured number, compound 4's estimate is 1.3-fold (0.12 log units) below it, within the range that was stated.
By their numbers in this assay, from the lowest: compounds 1, 2 and 4 (each within the scatter of the next); then compound 3.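

In this assay the methoxy on this aromatic carbon, ortho to a methoxy group, can now be read as a single change, whereas compound 1 and compound 2 differ by two methoxy groups at once. Hydrogen in place of this methoxy gives a 1.2-fold higher number from compound 2 to compound 4 (0.09 log units; within the scatter) and stays within the scatter, while the one-place change on the other side of compound 4 gives a 1.4-fold higher number from compound 1 to compound 4 (0.15 log units; within the scatter) and also stays within the scatter, so with the 4-aminophenyl group on the carbonyl carbon, neither single methoxy change separates from the scatter, and no compound among 1, 2 and 4 goes against this. The data shown offer no explanation for this result.

The compounds shown leave open whether a hydroxyl, an amine or a longer alkoxy chain on this aromatic carbon would also stay within the scatter of compound 2. They also leave open whether the same methoxy change would read the same way with the 3,4-dichlorophenyl group of compound 3 on the carbonyl carbon, where the number is much higher.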